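The compounds below may be only part of what the source reports. "The series", "measured", "known", "first", "only" and "open" are said of these compounds alone.

Among the compounds with values here, compound 3 `N#C[Se]c1ccc(NC(=O)Oc2ccc(Cl)cc2)cc1` gives 26300 nM in a functional assay on MCF7 cells (Homo sapiens) for cytotoxicity, read by MTT assay, with a stated time of 72 h (on this read-out higher numbers stand for weaker inhibition of growth and lower numbers for stronger inhibition of growth), a number at the low end of the three measured so far. Compound 1 `N#C[Se]c1ccc(NC(=O)Oc2ccccc2)cc1` gives 35900 nM in this assay, and compound 2 `Cc1ccc(OC(=O)Nc2ccc([Se][Se]c3ccc(NC(=O)Oc4ccc(C)cc4)cc3)cc2)cc1` gives 37700 nM in this assay; both sit within the scatter of compound 3. Compound 4 `COc1ccc(OC(=O)Nc2ccc([Se]C#N)cc2)cc1` differs from compound 3 in one place: methoxy in place of chloro on an aromatic carbon. Within the data shown here, the only step that bears on this position, a 1.4-fold lower number from compound 1 to compound 3 (0.14 log units; within the scatter), stayed within the scatter, so no change beyond the scatter is expected here in this assay. Compound 4 is therefore estimated at 28000 nM, with a range from 14000 nM to 56000 nM, which means an expected step of a 1.1-fold higher number from compound 3 to compound 4 (0.03 log units; within the scatter).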

Compound 4, concentration for total growth inhibition: 48200 nM
Estimate against measurement, compound 4: 1.7-fold (0.24 log units) below; measured number inside the range.
By their numbers in this assay, from the lowest: compounds 3, 1, 2 and 4 (each within the scatter of the next).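

In this assay, methoxy in place of chloro gives a 1.8-fold higher number from compound 3 to compound 4 (0.26 log units; within the scatter), and methoxy in place of hydrogen gives a 1.3-fold higher number from compound 1 to compound 4 (0.13 log units; within the scatter). With hydrogen, chloro and methoxy now seen on this aromatic carbon, all three compounds lie within the scatter of one another, so even a group that brings a hydrogen-bond acceptor produces no change beyond the scatter. No evidence bears on this result.

The compounds shown leave open whether an amine, a carboxylic acid or a longer chain on this carbon would move the number beyond the scatter.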